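Inverting the 1-methoxyethyl stereocentre of compound 3

The source may hold more compounds than are shown below. What is called first, only, known or untested is meant among the compounds shown, and "the series" means these compounds.

Compound 3 `CO[C@@H](C)c1cc(-c2noc([C@H](C)NC(=O)c3cc(C(F)(F)F)nn3C)n2)ccn1` stands highest in an assay on T-REx-293 cells for inhibition of potassium channel subfamily T member 1 (Homo sapiens), read by patch clamp (a higher number here means a weaker inhibitor, a lower number a stronger inhibitor), among the three compounds measured, giving 744 nM. Compound 1 `C[C@H](NC(=O)c1cc(C(F)(F)F)nn1C)c1nc(-c2cccc(F)c2)no1` gives 136 nM and compound 2 `Cc1cc(-c2noc([C@H](C)NC(=O)c3cc(C(F)(F)F)nn3C)n2)ccn1` gives 165 nM; the steps of a 5.5-fold higher number from compound 1 to compound 3 (0.74 log units; beyond the scatter) and a 4.5-fold higher number from compound 2 to compound 3 (0.65 log units; beyond the scatter) were both modest but beyond the scatter, while a 1.2-fold higher number from compound 1 to compound 2 (0.08 log units; within the scatter) stayed within it. Compound 4 `CO[C@H](C)c1cc(-c2noc([C@H](C)NC(=O)c3cc(C(F)(F)F)nn3C)n2)ccn1` is the next step: the two compounds have the same atoms and bonds and differ only in configuration as drawn: 1 of 2 stereo elements differ; a stereocentre at a saturated chain carbon is drawn S in compound 3 and R in compound 4. Going by the values given here, no measured pair differs only in configuration, so none of the measured steps bears directly on this change; the 1-methoxyethyl group is retained, and compound 3 is the only measured compound carrying it. Compound 4 is therefore expected to give 550 nM, within 150 nM to 2500 nM, an estimated step of a 1.4-fold lower number from compound 3 to compound 4 (0.13 log units; within the scatter) in this assay. Among the compounds with values here, the range is kept wide; no measured step shows what configuration does here.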

Compound 4, half-maximal inhibitory concentration: 778 nM
Compound 4: middle estimate off by 1.4-fold (0.15 log units), on the low side; low and high end bracket the measured number.
By their numbers in this assay, from the lowest: compounds 1 and 2 (each within the scatter of the next); then compounds 3 and 4 (each within the scatter of the next).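

In this assay, going by these compounds alone, configuration at the 1-methoxyethyl carbon makes no visible difference, a 1.0-fold higher number from compound 3 to compound 4 (0.02 log units; within the scatter), the first pair to test it alone: the fact that compounds 3 and 4 differ only in the configuration as drawn. The change from methyl to 1-methoxyethyl weakens inhibition in both configurations, a 4.7-fold higher number from compound 2 to compound 4 (0.67 log units; beyond the scatter), alongside a 4.5-fold higher number from compound 2 to compound 3 (0.65 log units; beyond the scatter). The gap to the 3-fluorophenyl compound also persists with the inverted centre, a 5.7-fold higher number from compound 1 to compound 4 (0.76 log units; beyond the scatter).

From the compounds shown here alone, whether a 1-hydroxyethyl or 1-aminoethyl group would return the number to that of compound 2 remains open. So does the role of the second stereocentre.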